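Swapping thiophen-2-yl for thiophen-3-yl in a cell assay

The compounds below may be only part of what the source reports. "The series", "measured", "known", "first", "only" and "open" are said of these compounds alone.

Measured in a functional assay on HCT-116 cells (Homo sapiens), read by MTT assay, with a stated time of 72 h; a higher number here means a weaker inhibitor, a lower number a stronger inhibitor:
- compound 1 `Nc1nc2c(c(-c3ccco3)cn2[C@@H]2O[C@H](CO)[C@@H](O)[C@H]2O)c(=O)[nH]1`: > 20000 nM (a limit, not a number)
- compound 2 `Nc1nc2c(c(-c3cccs3)cn2[C@@H]2O[C@H](CO)[C@@H](O)[C@H]2O)c(=O)[nH]1`: 19800 nM

For the measured compounds named here, compound 2, at 19800 nM, holds the only true number so far, and a high number here means a weak inhibitor. Compound 3 `Nc1nc2c(c(-c3ccsc3)cn2[C@@H]2O[C@H](CO)[C@@H](O)[C@H]2O)c(=O)[nH]1` has the same atoms as compound 2, joined differently: thiophen-3-yl in place of thiophen-2-yl on an aromatic carbon. Thiophen-3-yl stands in place of thiophen-2-yl on an aromatic carbon, and the rest of the molecule stays the same.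

Going by the values given here, only one measured step bears on this change: a number no higher from compound 1 to compound 2 (the limit leaves the size open). That step exchanged furan-2-yl for thiophen-2-yl on the same carbon. Its size cannot be read because of the limit of > 20000 nM in this assay, at which 1 of the 2 values shown sits. It therefore offers no size to carry over to the new change. With compound 2 at 19800 nM as the sole anchor, no step beyond the usual scatter is expected in this assay. The expected move is a 1.2-fold lower number from compound 2 to compound 3 (0.07 log units; within the scatter). Compound 3 is estimated at 17000 nM, with an expected range from 6000 nM to 20000 nM.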

Compound 3, half-maximal inhibitory concentration: > 20000 nM
Compound 3: only a limit was reported; the forecaster's own chance of this, stated with the estimate: 45%; middle value at least 1.1-fold (0.07 log units) from the limit.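

In this assay, moving the attachment from thiophen-2-yl to thiophen-3-yl gives a number no lower from compound 2 to compound 3 (the limit leaves the size open), so on this aromatic carbon the thiophen-3-yl group brings no stronger inhibition than thiophen-2-yl, something the first two compounds could not show. Compound 3 gives only a limit, > 20000 nM, and not a true number. The size of that step cannot be read, and the step between compound 1 and compound 3 cannot be read at all, because of what the limit does to this series: the limit of > 20000 nM in this assay, at which 2 of the 3 values shown sit.

The compounds shown leave open whether any group on this carbon other than these five-membered aromatic rings, such as an amine, a phenyl ring or a longer alkyl chain, would give a number far from the limit in this assay. They also leave open how much weaker compound 1 and compound 3 really are, as their true values lie beyond the range that this read-out reports.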